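A few compounds are considered here, and "the series" means these few. Any claim that something is new, unique, unknown or untested is made for them only; others in the source may bear on it.

Measured compounds:
compound 1 `COc1ccccc1Oc1ccc2c(NCCCNCc3ccco3)ccnc2c1`: 6500 nM
compound 2 `COc1ccc(F)cc1CNCCCNc1ccnc2cc(CCc3ccccc3)ccc12`: 4240 nM
compound 3 `COc1cccc(Oc2ccc3c(NCCCNCc4cccc(OC)c4O)ccnc3c2)c1`: 5300 nM

All three values come from an ADME assay on HepG2 cells (Homo sapiens) for cytotoxicity, read by luminescence, CellTiter-Glo and ATP content, with a stated time of 72 h; a lower number here means that less compound is needed, a higher number that more compound is needed for the effect. Compound 1 gives the highest number of the three, yet its gap to compound 3 and to compound 2 stays within the scatter, so no order among them can be read. Compound 4 `COc1ccc(Oc2ccc3c(NCCCNCc4ccco4)ccnc3c2)cc1` has not been measured; it differs from compound 1 as follows: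

4-methoxyphenyl in place of 2-methoxyphenyl on an oxygen on an aromatic ring

No change of this kind has been measured within the series, so the expected step is not anchored by any pair. The reworking of the same atoms is expected to leave the cytotoxicity number close to that of compound 1, with no step beyond the scatter in either direction, giving an expected step of a 1.1-fold lower number from compound 1 to compound 4 (0.03 log units; within the scatter). For compound 4 in this assay the estimate is 6000 nM, with a range from 3000 nM to 12000 nM.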

Compound 4, half-maximal effective concentration: 5300 nM
For compound 4 the middle estimate is 1.1-fold (0.05 log units) above the measured one; the range from low to high includes it.
By their numbers in this assay, from the lowest: compounds 2, 3, 4 and 1 (each within the scatter of the next).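

Among the compounds shown here, compounds 1 and 4 form the only pair that differs in one place. In this assay, 4-methoxyphenyl in place of 2-methoxyphenyl on an oxygen on an aromatic ring gives a 1.2-fold lower number from compound 1 to compound 4 (0.09 log units; within the scatter), so this reworking of the same atoms does not separate the two compounds. No measured property bears on this result.

Going by these compounds, it remains open whether an amine or a carboxylic acid on this ring would move the number beyond the scatter. On these data alone, whether the same swap behaves alike with a group other than the furan-bearing side chain also remains open.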